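Sulfonyl aryl variation on the shared core: cytotoxicity notes

This account rests on a few compounds, and the source may have more. Where it says the series, first, only, none or still open, it means among the compounds named here.

Measured so far:
compound 1 `CC1CCN(C2CCN(S(=O)(=O)c3cccc(Br)c3)CC2)CC1` — a limit in an ADME assay on HCT-116 cells (Homo sapiens) for cytotoxicity, read by CellTiter-Glo, with a stated time of 72 h (on this read-out lower numbers stand for stronger inhibition and higher numbers for weaker inhibition), of > 5000 nM
compound 2 `CCc1ccc(S(=O)(=O)N2CCC(N3CCC(C)CC3)CC2)cc1` — a limit of > 5000 nM
compound 3 `CC1CCN(C2CCN(S(=O)(=O)c3cncc(Br)c3)CC2)CC1` — a limit of > 10000 nM

Compound 3 sits at the limit of > 10000 nM in this assay, at which 1 of the 3 values shown sits. The other two values sit at the limit of > 5000 nM in this assay, at which 2 of the 3 values shown sit. No value here is a number.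

The next change, (hydrogen in place of bromo on an aromatic carbon), gives compound 4 `CC1CCN(C2CCN(S(=O)(=O)c3cccnc3)CC2)CC1`. Among the measured compounds shown here, the steps that bear on it all join limit to limit: a step that the two limits leave unreadable from compound 1 to compound 3, a step that the two limits leave unreadable from compound 2 to compound 3 and a step that the two limits leave unreadable from compound 1 to compound 2. None of them has a readable size or direction, so no step beyond the scatter can be expected in this assay, and a further limit is the likeliest outcome.

Compound 4 is expected to give 15000 nM, within 5000 nM to 50000 nM. The expected step that the limit leaves unreadable from compound 3 to compound 4 is therefore no more than an estimate between two limits.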

Compound 4, half-maximal inhibitory concentration: > 10000 nM
Compound 4: no number, only a limit; the forecaster's own chance of this, stated with the estimate: 85%; the middle value lies beyond the limit too.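

In this assay, compound 4 gives only a limit, as do compound 1, compound 2 and compound 3, so none of the steps to compound 4 can be read. The compounds shown leave open whether any sulfonyl aryl change on the shared core shifts cytotoxicity, and in which direction.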